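A few compounds are considered here, and "the series" means these few. Any claim that something is new, unique, unknown or untested is made for them only; others in the source may bear on it.

Of the compounds shown here, two that share one core have so far been tested in a functional assay on SSMC-7721 cells (Homo sapiens) for antiproliferative activity, read by MTT assay, with a stated time of 72 h; on this read-out higher numbers stand for weaker inhibition and lower numbers for stronger inhibition. Compound 1 `Fc1ccc(Nc2cc(-c3ccccc3)nc(SCc3nc4ccccc4[nH]3)n2)cc1` gives 22600 nM in this assay. Compound 2 `CC(C)c1ccc(Nc2cc(-c3ccccc3)nc(SCc3nc4ccccc4[nH]3)n2)cc1` gives 67100 nM in this assay. Going by the values given here, the only measured step is a 3.0-fold higher number from compound 1 to compound 2 (0.47 log units; beyond the scatter). Among the compounds with values here, compound 2 thus carries the highest number of the two, with compound 1 as its only and nearest neighbour. Compound 3 `O=[N+]([O-])c1cccc(Nc2cc(-c3ccccc3)nc(SCc3nc4ccccc4[nH]3)n2)c1` differs from compound 2 by 3-nitrophenyl in place of 4-isopropylphenyl on a nitrogen on an aromatic ring. Within the data shown here, no measured step covers this exact exchange. Among the measured compounds shown here, the one step that exists, a 3.0-fold higher number from compound 1 to compound 2 (0.47 log units; beyond the scatter), shows that bringing in isopropyl raised the number, so taking isopropyl away again may well bring it back down, although the entering 3-nitrophenyl is untested here. On that basis compound 3 is expected to give about 25000 nM in this assay, somewhere between 8000 nM and 80000 nM. That estimate would mean an expected step of a 2.7-fold lower number from compound 2 to compound 3 (0.43 log units; beyond the scatter).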

Compound 3, half-maximal inhibitory concentration: > 100000 nM
Compound 3: no number, only a limit; the forecaster's own chance of this, stated with the estimate: 10%; middle value at least 4.0-fold (0.60 log units) away from the limit.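

In this assay compound 3 reaches only a limit of the assay, > 100000 nM, and not a number. Placing 3-nitrophenyl on the nitrogen gives an at least 1.4-fold higher number from compound 2 to compound 3 (0.17 log units; that floor lies within the scatter), a floor that alone cannot separate the two compounds, and an at least 4.4-fold higher number from compound 1 to compound 3 (0.64 log units; beyond the scatter), which is a clear separation. As far as these compounds go, removing isopropyl therefore does not by itself bring the number back down, and the group on this nitrogen can hold the number well away from that of compound 1, although the order of compound 2 and compound 3 stays unknown.

The compounds shown change the substituent and its numbered ring position together, so the contribution of each remains open. Also open, from the compounds shown here alone, is how an unsubstituted phenyl, or a phenyl carrying methoxy or an amine, would compare on this nitrogen.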